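This account rests on a few compounds, and the source may have more. Where it says the series, first, only, none or still open, it means among the compounds named here.

Among the compounds with values here, compound 3 `CC(C)=CCCC1=CC[C@@H](C(=O)NCCC(=O)O)[C@H](c2ccccc2)C1` is one of three compounds measured in an assay on isolated protein for inhibition of Apoptosis regulator Bcl-2 (Homo sapiens), read by fluorescence polarization, with stated times of 5 min and 10 min; on this read-out lower numbers stand for stronger inhibition and higher numbers for weaker inhibition. In this assay compound 3 reaches only the limit > 23000 nM. Compound 1 `CC(C)=CCCC1=CC[C@H](C(=O)N(C)O)[C@@H](c2ccccc2)C1` gives 2100 nM in this assay. Compound 2 `CC(C)=CCCC1=CC[C@H](C(N)=O)[C@@H](c2ccccc2)C1` reaches only the limit > 23000 nM in this assay. Within the data shown here, the single measured step, an at least 10-fold higher number from compound 1 to compound 2 (1.03 log units; beyond the scatter), changes the group on the carbonyl carbon and not the ring configuration, so no measured step bears directly on the change to compound 4 `CC(C)=CCCC1=CC[C@H](C(=O)NCCC(=O)O)[C@@H](c2ccccc2)C1`, in which (the two compounds have the same atoms and bonds and differ only in configuration as drawn: 2 of 2 stereo elements differ (all stereocentres are inverted: mirror images); a stereocentre at a saturated ring carbon is drawn R in compound 3 and S in compound 4; a stereocentre at a saturated ring carbon is drawn R in compound 3 and S in compound 4). Compound 1 shares the drawn configuration of compound 4 but carries the hydroxy(methyl)amino group that compound 2 lacks. Most of the numbers rest at the limit of > 23000 nM in this assay, at which 2 of the 3 values shown sit. Compound 4 is therefore expected to give 20000 nM (range 7000 nM to 60000 nM), a step of an at least 1.1-fold lower number from compound 3 to compound 4 (0.06 log units; that floor lies within the scatter) estimated to stay within the scatter.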

Compound 4, inhibition constant: > 23000 nM
Compound 4: only a limit was reported (the forecaster's own chance of this, stated with the estimate: 70%); middle value at least 1.1-fold (0.06 log units) away from the limit.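

In this assay compound 4 reaches only a limit, > 23000 nM. Replacing hydroxy(methyl)amino with (2-carboxyethyl)amino on the carbonyl carbon gives an at least 10-fold higher number from compound 1 to compound 4 (1.03 log units; beyond the scatter), so a second replacement of that group, after amino, also ends without a measurable value. The steps to compound 4 from compound 2 and compound 3 cannot be read because both ends of each are limits: the limit of > 23000 nM in this assay, at which 3 of the 4 values shown sit.

Going by these compounds, whether the drawn configuration matters therefore stays open, even for this mirror-image pair. Also open, on these data alone, is whether an amine in place of the carboxylic acid at the chain end, or a longer chain, would give a measurable value.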